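Amine variation on the thiocarbonyl carbon, series notes

The source may report more compounds than this note shows. Statements on the series, on what has been measured and on what is new or still open speak of the compounds shown alone.

Measured so far:
compound 1, `COc1ccc2oc(CSC(=S)N3CCOCC3)cc(=O)c2c1`, > 25000 nM
compound 2, `COc1ccc2oc(CSC(=S)N(C(C)C)C(C)C)cc(=O)c2c1`, > 25000 nM

In a functional assay on HeLa cells (Homo sapiens) for antiproliferative activity, read by MTT assay, with a stated time of 72 h (a lower number here means a stronger inhibitor, a higher number a weaker inhibitor), compound 1 gives > 25000 nM, which is a limit of the assay and not a number. Compound 2 gives > 25000 nM, likewise a limit. The step from compound 1 to compound 2 is a step that the two limits leave unreadable from compound 1 to compound 2. Compound 2 therefore stands at the limit of > 25000 nM in this assay, at which 2 of the 2 values shown sit, with no number of its own in this assay.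

The next compound, compound 3, is `COc1ccc2oc(CSC(=S)N3CCCCC3)cc(=O)c2c1`. It differs from compound 2 by piperidin-1-yl in place of diisopropylamino on a thiocarbonyl carbon. Going by the values given here, the only measured step on this position is a step that the two limits leave unreadable from compound 1 to compound 2, and it gives no readable size, so nothing points to a change beyond the scatter.

Compound 3 is therefore expected to sit at the same limit in this assay, with an estimate of 40000 nM and a range of 15000 nM to 150000 nM. The expected step that the limit leaves unreadable from compound 2 to compound 3 is none beyond the scatter, and most likely compound 3 again gives only a limit.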

Compound 3, half-maximal inhibitory concentration: 11900 nM
Compound 3: the middle estimate sits 3.4-fold (0.53 log units) above what was measured; the whole stated range lies above it.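

In this assay this position now gives a readable result: piperidin-1-yl in place of diisopropylamino on a thiocarbonyl carbon gives an at least 2.1-fold lower number from compound 2 to compound 3 (0.32 log units; beyond the scatter), and piperidin-1-yl in place of morpholin-4-yl gives an at least 2.1-fold lower number from compound 1 to compound 3 (0.32 log units; beyond the scatter). Both sizes are lower bounds, as each step starts from a compound held at a limit, and the step between compound 1 and compound 2 cannot be read. A ring on this carbon is not enough by itself, as the morpholin-4-yl of compound 1 also carries one and stays at the limit: the limit of > 25000 nM in this assay, at which 2 of the 3 values shown sit.

On these data alone, it remains open whether pyrrolidin-1-yl, 4-methylpiperazin-1-yl or the open-chain diethylamino would give a readable value on this carbon. As far as these compounds go, the true size of the difference between compound 3 and the two compounds at the limit also remains open.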